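The source may hold more compounds than are shown below. What is called first, only, known or untested is meant among the compounds shown, and "the series" means these compounds.

Of the compounds shown here, two built on a shared core have been tested in a functional assay on SF-268 cells (Homo sapiens) for antiproliferative activity; a lower number here means a stronger inhibitor of growth, a higher number a weaker inhibitor of growth. Compound 1 `CCOC(=O)C[C@H]1[C@@H](O[Si](C)(C)C(C)(C)C)[C@H](n2cnc3c(NC(=O)Nc4ccccc4)ncnc32)O[C@@H]1COC(=O)NC` gives 5.06 nM in this assay. Compound 2 `CNC(=O)NC[C@H]1O[C@@H](n2cnc3c(NC(=O)Nc4ccccc4)ncnc32)[C@H](O[Si](C)(C)C(C)(C)C)[C@@H]1CC(=O)N(C)OC` gives 8.29 nM in this assay; this is the higher of the two numbers, but its gap to compound 1 lies within the usual scatter of repeated measurements, so the two compounds cannot be told apart on these data. A third compound, compound 3 `CCOC(=O)C[C@H]1[C@@H](O[Si](C)(C)C(C)(C)C)[C@H](n2cnc3c(NC(=O)Nc4ccccc4)ncnc32)O[C@@H]1CNC(=O)NC`, has not been measured yet. It differs from compound 2 in one place: ethoxy in place of methoxy(methyl)amino on a carbonyl carbon. Within the data shown here, compound 1 already carries an ethoxycarbonyl group and stands close to compound 2, so nothing in the numbers so far suggests that this exchange moves the value far in either direction. The step of a 1.4-fold lower number from compound 2 to compound 3 (0.14 log units; within the scatter) is therefore expected to stay within the scatter. Compound 3 is estimated at 6 nM, with a likely range from 2.5 nM to 15 nM.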

Compound 3, concentration for 50% growth inhibition: 6.53 nM
Compound 3: middle estimate off by 1.1-fold (0.04 log units), on the low side; the measured number falls inside the stated range.
By their numbers in this assay, from the lowest: compounds 1, 3 and 2 (each within the scatter of the next).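

In this assay, the exchange of methoxy(methyl)amino for ethoxy on a carbonyl carbon can now be read directly: it gives a 1.3-fold lower number from compound 2 to compound 3 (0.10 log units; within the scatter) and so separates neither compound from the other. Among these compounds, compound 3 also allows a first one-place comparison with compound 1, where (methylcarbamoyl)amino in place of (methylcarbamoyl)oxy gives a 1.3-fold higher number from compound 1 to compound 3 (0.11 log units; within the scatter) and again leaves the pair indistinguishable. No supporting measurement here explains either result.

Among the compounds shown here, the data show only that these two groups on the carbonyl carbon cannot be told apart, so it remains open whether a much different group would also fit there. A hydroxyl, giving a carboxylic acid, or a longer alkoxy chain such as butoxy could move the value well beyond the scatter or leave it within it.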